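The compounds below may be only part of what the source reports. "The series", "measured", "known", "first", "only" and "open" are said of these compounds alone.

Compound 1 `Cc1c(C(=O)N=C(N)N)cc(S(C)(=O)=O)c(Cl)c1[N+](=O)[O-]` and compound 2 `Cc1cc(-c2ccc(Cl)cc2)c(S(C)(=O)=O)cc1C(=O)N=C(N)N` share a core carrying a methylsulfonyl group and an acylguanidine. In a functional assay for inhibition of sodium/hydrogen exchanger (Oryctolagus cuniculus) (on this read-out higher numbers stand for weaker inhibition and lower numbers for stronger inhibition), compound 1 gives 44 nM, and in this assay compound 2 gives 45 nM; compound 2 holds the higher of the two numbers, yet the gap to compound 1 lies within the scatter. Compound 3 `Cc1cc(OC(C)C)c(S(C)(=O)=O)cc1C(=O)N=C(N)N` differs from compound 2 by isopropoxy in place of 4-chlorophenyl on an aromatic carbon. Among the compounds with values here, no measured pair shows this exchange, so the expected step is only a 1.4-fold higher number from compound 2 to compound 3 (0.16 log units; within the scatter). Compound 3 is therefore estimated at 65 nM, within 20 nM to 220 nM.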

Compound 3, half-maximal inhibitory concentration: 19 nM
Beside the measured number, compound 3's estimate is 3.4-fold (0.53 log units) above it; measured number outside the range, below it.
By their numbers in this assay, from the lowest: compound 3; then compounds 1 and 2 (each within the scatter of the next).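

On an aromatic carbon ortho to a methylsulfonyl group, in this assay, isopropoxy in place of 4-chlorophenyl gives a 2.4-fold lower number from compound 2 to compound 3 (0.37 log units; beyond the scatter) and so a modest move toward stronger inhibition. This position therefore does not need the aromatic ring of 4-chlorophenyl to reach numbers of this size, and a group with no ring and fewer heavy atoms serves here. The data shown offer no explanation for this step. Going by these compounds, it stays open whether the oxygen of isopropoxy or its branched carbon chain matters, and an isopropyl group, a methoxy group or an amine on this carbon would help separate the two.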